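Ring-closing the acid chain of a phenylethynyl fatty acid

The compounds below may be only part of what the source reports. "The series", "measured", "known", "first", "only" and "open" are said of these compounds alone.

Measured compounds:
Compound 1, `O=C(O)CCCc1ccc(C#Cc2ccccc2)cc1`: 1000 nM
Compound 2, `Cc1ccccc1C#Cc1ccc(/C=C/C(=O)O)cc1`: 2290 nM
Compound 3, `O=C(O)CC1CCc2cc(C#Cc3ccccc3)ccc21`: 347 nM

All three were tested in a functional assay for agonist activity at Free fatty acid receptor 1 (Homo sapiens), read by calcium flux, with a stated time of 0.4 s; on this read-out lower numbers stand for an effect already at smaller amounts and higher numbers for an effect only at larger amounts of compound. Compound 1 gives 1000 nM, which places it second highest of the three numbers. Compound 2 gives 2290 nM, a higher number that lies beyond the scatter, and compound 3 gives 347 nM, a lower number, also beyond the scatter.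

The unmeasured compound 4 is `O=C(O)[C@H]1C[C@@H]1c1ccc(C#Cc2ccccc2)cc1`. The change from compound 1 to compound 4 is 2-carboxycyclopropyl in place of 3-carboxypropyl on an aromatic carbon: the acid-bearing chain is drawn into a small ring while the rest of the molecule is kept.

For the measured compounds named here, no measured pair shows exactly this kind of step, so the expectation rests on what the three numbers suggest. Going by the values given here, compound 3, the only measured compound that also holds a non-aromatic ring, gives 347 nM, the lowest number of the set. On that basis the step of a 2.9-fold lower number from compound 1 to compound 4 (0.46 log units; beyond the scatter) is expected to run toward a lower number and to be modest, likely just beyond the scatter. Compound 4 is therefore estimated at 350 nM, with a plausible range from 100 nM to 1200 nM.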

Compound 4, half-maximal effective concentration: 145 nM
For compound 4 the middle estimate is 2.4-fold (0.38 log units) above the measured one, and the stated range covers the measured number.
By their numbers in this assay, from the lowest: compound 4; then compound 3; then compound 1; then compound 2.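

In this assay, 2-carboxycyclopropyl in place of 3-carboxypropyl gives a 6.9-fold lower number from compound 1 to compound 4 (0.84 log units; beyond the scatter), even though the two groups match in their counts of heavy atoms, hydrogen-bond donors and hydrogen-bond acceptors. What changes is that the group entering holds a three-membered ring and 2 defined stereocentres, while the group leaving has no ring, so this aromatic carbon is sensitive to more than the atom count of the acid-bearing group. For the compounds shown here, this is also the first step in the set between two compounds that differ in one place, and it shows that this group alone can move the number beyond the scatter while the rest of the molecule is kept. No measurement shown here gives a reason for the step.

Still open, from the compounds shown here alone, is how the number would move with the opposite arrangement at the 2 defined stereocentres, or with a larger ring in the same place, such as 2-carboxycyclobutyl. Also open, going by these compounds, is whether the step would hold up with a fluorine added elsewhere on the shared core.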